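The compounds below may be only part of what the source reports. "The series", "measured", "known", "first", "only" and "open" are said of these compounds alone.

Measured compounds:
compound 1, `Cc1c(OCCCCOc2ccc(C(=O)O)cc2)ccc(C(=O)CC(C)C)c1O`, 51.9%;
compound 2, `Cc1cc(C(=O)O)ccc1OCCCCOc1ccc(C(=O)CC(C)C)c(O)c1C`, 42.1%.

In an assay on HEK293 cells for positive allosteric modulation of metabotropic glutamate receptor 3 (Rattus norvegicus), read by thallium flux, with a stated time of 2.5 min (on this read-out lower numbers stand for smaller maximal responses and higher numbers for larger maximal responses), compound 2 gives 42.1%, and compound 1 gives 51.9%, the two numbers lying within the scatter of each other. Compound 3, `Cc1cc(OCCCCOc2ccc(C(=O)CC(C)C)c(O)c2C)ccc1C(=O)O`, has not been measured. It differs from compound 2 in one place: 4-carboxy-3-methylphenyl in place of 4-carboxy-2-methylphenyl on an oxygen on a saturated carbon. Among the measured compounds shown here, the only measured step, a number 9.8 percentage points lower from compound 1 to compound 2 (within the scatter), concerns a methyl entering an aromatic carbon and stays within the scatter; no step in which a methyl moves from one aromatic carbon to another has been measured. On that basis no change beyond the scatter is expected for compound 3 in this assay, and the step is estimated as a number 2.9 percentage points higher from compound 2 to compound 3 (within the scatter). Compound 3 is therefore expected to reach 45%, between 30% and 60%.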

Compound 3, largest response reached (reported as percent of maximum), in percent of the reference or control that the assay uses: 41.9%
For compound 3 the middle estimate is 3.1 percentage points above the measured one; measured number inside the range.
By their numbers in this assay, from the lowest: compounds 3, 2 and 1 (each within the scatter of the next).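

In this assay, among the compounds shown here, the change from 4-carboxy-2-methylphenyl to 4-carboxy-3-methylphenyl on the oxygen gives a number 0.2 percentage points lower from compound 2 to compound 3 (within the scatter), the first measured step in which the methyl moves from one aromatic carbon to another. Methyl in place of hydrogen at this other aromatic carbon gives a number 10 percentage points lower from compound 1 to compound 3 (within the scatter), so both methyl placements can now be read against compound 1, and neither step leaves the scatter. Across these compounds, then, neither the presence of this methyl nor its placement shows a change in the maximal response beyond the scatter, and no available evidence bears on the reason for this result.

From the compounds shown here alone, whether chlorine, methoxy or an ethyl group on this ring would behave as the methyl does remains open. So does whether a longer chain on the oxygen would shift the response beyond the scatter.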